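Fluoro for dimethylamino on the aryl thiosemicarbazone

This account rests on a few compounds, and the source may have more. Where it says the series, first, only, none or still open, it means among the compounds named here.

Compound 1 `COc1ccc(/C=N/NC(=S)NC(C)(C)[C@H]2CC=C(C)CC2)cc1` gives 30700 nM in a functional assay on K562 cells (Homo sapiens) for inhibition, read by sulforhodamine B assay, with a stated time of 48 h; on this read-out lower numbers stand for stronger inhibition of growth and higher numbers for weaker inhibition of growth. Compound 2 `CC1=CC[C@H](C(C)(C)NC(=S)N/N=C/c2ccccc2O)CC1` reaches only the limit of the assay at > 100000 nM. Compound 3 `CC1=CC[C@H](C(C)(C)NC(=S)N/N=C/c2ccc(N(C)C)cc2)CC1` likewise stops at the limit, > 100000 nM, so compound 3 stands at the weak end of the three values shown, with no number of its own; it shares this position with compound 2 (the limit of > 100000 nM in this assay, at which 2 of the 3 values shown sit). Compound 4 `CC1=CC[C@H](C(C)(C)NC(=S)N/N=C/c2ccc(F)cc2)CC1` is the untested partner: fluoro in place of dimethylamino on an aromatic carbon. For the measured compounds named here, two measured steps bear on this change: an at least 3.2-fold higher number from compound 1 to compound 2 (0.51 log units; beyond the scatter) and an at least 3.2-fold higher number from compound 1 to compound 3 (0.51 log units; beyond the scatter); both leave compound 1 as the only member with a measured number. Since compound 3 sits at a limit, the step to compound 4 is expected to be at most a modest movement towards a lower number, an at least 2.0-fold lower number from compound 3 to compound 4 (0.30 log units; that floor lies within the scatter), with a real chance that compound 4 also stops at the limit. Compound 4 is therefore estimated at 50000 nM, between 15000 nM and 150000 nM.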

Compound 4, concentration for total growth inhibition: > 100000 nM
Compound 4 gave a limit, no number; the forecaster's own chance of this, stated with the estimate: 45%; middle value at least 2.0-fold (0.30 log units) away from the limit.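

Fluoro in place of methoxy on an aromatic carbon gives an at least 3.2-fold higher number from compound 1 to compound 4 (0.51 log units; beyond the scatter) in this assay. For the compounds shown here, at this place, para to a large group, dimethylamino and fluoro, which differ in their heavy atoms and hydrogen-bond acceptors, both leave the compound at a limit, so methoxy remains the only group here with a measured number. The steps from compound 2 and from compound 3 to compound 4 cannot be read, and the limit now takes in most of the series: the limit of > 100000 nM in this assay, at which 3 of the 4 values shown sit.

As far as these compounds go, whether an ethoxy, a hydroxy or a chloro at this place would give a measured number, and whether any of them would improve on compound 1, stays open. Also open, from the compounds shown here alone, is whether compound 2, compound 3 and compound 4 differ from one another beyond the limit.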